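The compounds below may be only part of what the source reports. "The series", "measured", "known", "first", "only" and "open" are said of these compounds alone.

Measured so far:
- compound 1, `CC1C(=O)N(CCCCCCCOc2ccc(Cl)cc2)/C(=N\C#N)N1c1ccncc1`, gives 370 nM in a functional assay on DLD-1 cells (Homo sapiens) for cytotoxicity; a lower number here means a stronger inhibitor, a higher number a weaker inhibitor
- compound 2, `N#C/N=C1\N(CCCCCOc2ccc(Cl)cc2)C(=O)C(c2ccccc2)N1c1ccncc1`, gives 337 nM in this assay

Compound 2 and compound 1 sit within the usual scatter of each other in this assay, so neither can be placed ahead of the other on these two numbers alone. Compound 3, `N#C/N=C1\N(CCCCCCCOc2ccc(Cl)cc2)C(=O)C(c2ccccc2)N1c1ccncc1`, has not yet been measured in this assay. It differs from compound 2 in one place: 2-(4-chlorophenoxy)ethyl in place of 4-chlorophenoxy on a saturated chain carbon, five bonds along the chain from an amide-type nitrogen in a ring. For the measured compounds named here, no measured pair shows this exact change, so its effect is unknown. Going by the values given here, the only guidance is that compound 1 and compound 2, which differ in more than one place, give nearly the same value, which suggests that the shared core tolerates some variation without a large shift. The step of a 1.0-fold higher number from compound 2 to compound 3 (0.00 log units; within the scatter) is therefore expected to be small, in no particular direction, and within the scatter. Compound 3 is estimated at 340 nM, with a range from 150 nM to 800 nM.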

Compound 3, half-maximal inhibitory concentration: 290 nM
Estimate against measurement, compound 3: 1.2-fold (0.07 log units) above; low and high end bracket the measured number.
By their numbers in this assay, from the lowest: compounds 3, 2 and 1 (each within the scatter of the next).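

In this assay, 2-(4-chlorophenoxy)ethyl in place of 4-chlorophenoxy on a saturated chain carbon, five bonds along the chain from an amide-type nitrogen in a ring, gives a 1.2-fold lower number from compound 2 to compound 3 (0.07 log units; within the scatter), so this added length of chain causes no readable shift. Compound 1 and compound 2 differ in more than one place, but compound 3 provides a single-change comparison with compound 1: phenyl in place of methyl on a saturated ring carbon gives a 1.3-fold lower number from compound 1 to compound 3 (0.11 log units; within the scatter), so this swap also causes no readable shift. Nothing available here explains why either change has so little effect.

On these data alone, it remains open whether a still longer chain would keep the number in this range. As far as these compounds go, it is equally open whether an amine or a carboxylic acid in place of the 4-chlorophenoxy end would do so.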